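This account rests on a few compounds, and the source may have more. Where it says the series, first, only, none or still open, it means among the compounds named here.

Of the compounds shown here, two of one shared core have been measured in an assay on HEK293 cells for displacement of a labelled ligand from metabotropic glutamate receptor 5 (Rattus norvegicus); a lower number here means a stronger inhibitor, a higher number a weaker inhibitor. Compound 1 `O=C(Nc1cc(-c2ccccc2)nn1-c1ccccc1)c1ccc([N+](=O)[O-])cc1` gives 250 nM, while compound 2 `O=C(Nc1cc(-c2ccccc2)nn1-c1ccccc1Br)c1ccccc1` gives 2600 nM, the highest of the two numbers, with a gap to compound 1 beyond the scatter. Compound 3 `O=C(Nc1cc(-c2ccccc2)nn1-c1ccccc1Br)c1ccc([N+](=O)[O-])cc1` has not yet been measured; it arises from compound 2 through (nitro in place of hydrogen on an aromatic carbon), which one bond further out reads phenyl to 4-nitrophenyl. Among the measured compounds shown here, compound 1 carries that nitro group and sits at the lower number, though it differs from compound 2 in two places, so no single step is known. Compound 3 is expected to show a step of a 2.9-fold lower number from compound 2 to compound 3 (0.46 log units; beyond the scatter), toward a lower number. For compound 3 the estimate in this assay is 900 nM, within 250 nM to 3000 nM.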

Compound 3, inhibition constant: 120 nM
The estimate for compound 3 lay 7.5-fold (0.88 log units) above the measured number; the whole stated range lies above it.
By their numbers in this assay, from the lowest: compound 3; then compound 1; then compound 2.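

In this assay, among the compounds shown here, 4-nitrophenyl in place of phenyl gives a 22-fold lower number from compound 2 to compound 3 (1.34 log units; beyond the scatter), which isolates the nitro group for the first time and shows a large step at this position on a ring otherwise unchanged. Bromo in place of hydrogen gives only a modest 2.1-fold lower number from compound 1 to compound 3 (0.32 log units; beyond the scatter) when the nitro group is present. Nothing given here explains either step.

On these data alone, whether an amine or a carboxylic acid at the same place would give a similar step remains open. The step for bromo without the nitro group cannot be read from these compounds.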